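The compounds below may be only part of what the source reports. "The series", "measured", "known", "first", "only" and "open" are said of these compounds alone.

The series shares one core with a cyclopropyl-bearing glycine amide; the ester end varies. Compound 1 `O=C(O)[C@@H]1CCCN1C(=O)CN(c1nc(Cl)nc2[nH]cnc12)C1CC1` gives 31.5% in a functional assay on the whole organism (Tail, strain ICR) with Mus musculus as the target, in the tail flick test, with a stated time of 30 min, at a dose of 25 umol/kg by the oral route; on this read-out lower numbers stand for a weaker effect and higher numbers for a stronger effect at the one dose given. Compound 2 `O=C(OCc1ccccc1)[C@@H]1CCCN1C(=O)CN(c1nc(Cl)nc2[nH]cnc12)C1CC1` gives 33.2%. For the measured compounds named here, the one step between compounds differing in a single place is a number 1.7 percentage points higher from compound 1 to compound 2 (within the scatter), which bears on the ester alone.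

Compound 3 `NC(=O)C[C@H](NC(=O)CN(c1ncnc2c1ncn2C1CCCCO1)C1CC1)C(=O)OCc1ccccc1` gives 34.5%. Its number is the highest of the three, yet it is within the scatter of compound 2 and within the scatter of compound 1, so no order among the three can be read from the numbers.

Compound 4 `CSCC[C@H](NC(=O)CN(c1ncnc2c1ncn2C1CCCCO1)C1CC1)C(=O)OCc1ccccc1` differs from compound 3 as follows: (methylsulfanyl)methyl in place of carbamoyl on a saturated chain carbon, two bonds along the chain from an amide-type nitrogen and a carbonyl carbon. Going by the values given here, no measured step changes this position; the only measured step, a number 1.7 percentage points higher from compound 1 to compound 2 (within the scatter), concerns the ester and was within the scatter, and it gives no guide to the side chain. The expectation for this assay therefore rests on the flat numbers of compounds 1, 2 and 3, and the step of a number 1.5 percentage points lower from compound 3 to compound 4 (within the scatter) is expected to stay within the scatter. Compound 4 is estimated at 33%, in the range 20% to 46%.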

Compound 4, a percentage reported as activity, at one dose (the size of the read-out at that dose, not a potency): 30%
For compound 4 the middle estimate is 3 percentage points above the measured one; measured number inside the range.
By their numbers in this assay, from the lowest: compounds 4, 1, 2 and 3 (each within the scatter of the next).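

For the compounds shown here, this is the first measured change at this position, on a saturated chain carbon, two bonds along the chain from an amide-type nitrogen and a carbonyl carbon. In this assay the exchange of carbamoyl for (methylsulfanyl)methyl gives a number 4.5 percentage points lower from compound 3 to compound 4 (within the scatter) and thus stays within the scatter, even though the hydrogen-bond donor of carbamoyl is lost and sulfur enters. No measurement at hand explains this result or links it to a property of either group.

From the compounds shown here alone, whether an amine or a carboxylic acid at this position, or a chain longer than 2-(methylsulfanyl)ethyl, would give a step beyond the scatter remains open. Also open, going by these compounds, is whether the same exchange would read alike on the core of compound 1.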